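From phenyl to 4-methoxyphenyl: one step, little guidance

The compounds below may be only part of what the source reports. "The series", "measured", "known", "first", "only" and "open" are said of these compounds alone.

Compound 1 `CC(=O)N1N=C(Nc2nc3ccccc3s2)CC1c1ccccc1` measured at 315 umol/kg
Compound 2 `CC(=O)N1N=C(Nc2nc3ccc([N+](=O)[O-])cc3s2)CC1c1ccccc1` measured at 216 umol/kg
Compound 3 `COc1ccc(C2CC(Nc3nc4ccccc4s3)=NN2C(C)=O)cc1` not yet measured

Within the data shown here, in a functional assay on the whole organism (Hindlimb, strain albino) with Mus musculus as the target, in the maximal electroshock model, with a stated time of 0.5 h (a higher number here means that more compound is needed for the effect, a lower number that less compound is needed), compound 1 gives 315 umol/kg as one of only two measured numbers. The two lie within the usual scatter of each other, so neither stands apart.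

Compound 3 differs from compound 1 by a single substitution (methoxy in place of hydrogen on an aromatic carbon): methoxy in place of hydrogen on an aromatic carbon, which turns phenyl into 4-methoxyphenyl. Among the measured compounds shown here, the only measured step is a different substitution, nitro in place of hydrogen on an aromatic carbon (a 1.5-fold lower number from compound 1 to compound 2 (0.16 log units; within the scatter)), and it stayed within the scatter. For the measured compounds named here, no measurement yet covers a change on the phenyl group, so that step offers only weak guidance. With so little to go on, no step beyond the scatter is expected in either direction, and the estimated step is small (a 1.1-fold lower number from compound 1 to compound 3 (0.05 log units; within the scatter)). The expected value for compound 3 is 280 umol/kg (estimated range 130 umol/kg to 600 umol/kg).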

Compound 3, dose for half-maximal effect: 226 umol/kg
Compound 3: middle estimate off by 1.2-fold (0.09 log units), on the high side; the range from low to high includes it.
By their numbers in this assay, from the lowest: compounds 2, 3 and 1 (each within the scatter of the next).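

In this assay, the first change tried on the phenyl group, methoxy in place of hydrogen para to a large group, gives a 1.4-fold lower number from compound 1 to compound 3 (0.14 log units; within the scatter). This place on the ring therefore accepts methoxy, with its 2 heavy atoms and its hydrogen-bond acceptor, without a step beyond the scatter, and the same holds so far for the nitro change on the other side of the molecule, a 1.5-fold lower number from compound 1 to compound 2 (0.16 log units; within the scatter). Nothing available explains this result or links it to any property of the methoxy group.

Going by these compounds, it remains open whether a group of a different kind at this place, such as an amine, a carboxylic acid or a longer chain like butoxy, would give a step beyond the scatter in this assay. Also open, on these data alone, is whether methoxy on the phenyl group and nitro on the other side of the molecule, each within the scatter alone, would give a clearer step when carried together by one compound.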